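This account rests on a few compounds, and the source may have more. Where it says the series, first, only, none or still open, it means among the compounds named here.

Working notes on the series.

Within the data shown here, compound 1 `CN(C(=O)NC(=O)c1cccc([N+](=O)[O-])c1)c1nc(C(F)(F)F)c(C(=O)N/N=C/c2ccccc2C(F)(F)F)s1` is the one member of the set with a measured number: in a functional assay on BCG823 cells (Homo sapiens) for inhibition, read by MTT assay, with a stated time of 72 h (a higher number here means a weaker inhibitor, a lower number a stronger inhibitor), compound 1 gives 3.97 ug/mL. The two other values are limits of the assay. Compound 2 `CNc1nc(C)c(C(=O)N/N=C/c2cccc(C(F)(F)F)c2)s1` gives > 100 ug/mL, a limit. Compound 3 `CNc1nc(C(F)(F)F)c(C(=O)N/N=C/c2cccc(C(F)(F)F)c2)s1` gives > 100 ug/mL, also a limit. Among the measured compounds shown here, the single step that can be drawn between measured compounds, trifluoromethyl in place of methyl on an aromatic carbon, is a step that the two limits leave unreadable from compound 2 to compound 3, and the reason it cannot be read is the limit of > 100 ug/mL in this assay, at which 2 of the 3 values shown sit.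

Compound 4 `CN(C(=O)NC(=O)c1ccc(Cl)cc1Cl)c1nc(C(F)(F)F)c(C(=O)N/N=C/c2ccccc2C(F)(F)F)s1` differs from compound 1 in one place: 2,4-dichlorophenyl in place of 3-nitrophenyl on a carbonyl carbon. For the measured compounds named here, no measured step touches this position; the one step in hand concerns another part of the shared core and is itself unreadable. There is therefore no basis for expecting movement in either direction, and the step from compound 1 to compound 4 is estimated to lie within the scatter, at a 1.1-fold higher number from compound 1 to compound 4 (0.05 log units; within the scatter). Compound 4 is accordingly expected to give about 4.5 ug/mL in this assay, within a range of 1.5 ug/mL to 14 ug/mL.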

Compound 4, half-maximal inhibitory concentration: 5.73 ug/mL
Compound 4: the middle estimate sits 1.3-fold (0.10 log units) below what was measured; the range from low to high includes it.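

In this assay, among these compounds, a 1.4-fold higher number from compound 1 to compound 4 (0.16 log units; within the scatter) is the first readable step and the first reading at the group on the carbonyl carbon. The hydrogen-bond acceptors counted for 3-nitrophenyl are absent from 2,4-dichlorophenyl, yet compound 1 and compound 4 cannot be told apart here, so this exchange on the shared core leaves the read-out within the scatter. Nothing in hand speaks to a cause for this step.

Still open, as far as these compounds go, is whether a group of another kind on this carbonyl carbon, such as an aminophenyl, a carboxyphenyl or a straight alkyl chain, would stay with these two compounds. The step from methyl to trifluoromethyl on the aromatic carbon remains unreadable, so that position has no reading yet.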